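Working notes on a small cytotoxicity series

The compounds below may be only part of what the source reports. "The series", "measured", "known", "first", "only" and "open" are said of these compounds alone.

Measured so far:
compound 1 `CCCCCCCCCCCCCCNc1nc(SCc2ccc(C(F)(F)F)cc2)nc2ccccc12` — > 50000 nM
compound 2 `FC(F)(F)c1ccc(CSc2nc(Nc3cccc(Br)c3)c3ccccc3n2)cc1` — 25600 nM

In a functional assay on MCF7 cells (Homo sapiens) for cytotoxicity, read by MTT assay, with a stated time of 72 h (a higher number here means a weaker inhibitor, a lower number a stronger inhibitor), compound 1 gives only a limit, > 50000 nM, and so sits at the limit of > 50000 nM in this assay, at which 1 of the 2 values shown sits. Among the compounds with values here, compound 2 gives 25600 nM in this assay; this is the only number in the set, and a weak one. Within the data shown here, no two measured compounds differ in a single place, so no measured step is available to lean on.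

Compound 3 `COc1ccc(Nc2nc(SCc3ccc(C(F)(F)F)cc3)nc3ccccc23)cc1OC` differs from compound 2 by 3,4-dimethoxyphenyl in place of 3-bromophenyl on a nitrogen on an aromatic ring. Among the measured compounds shown here, with no comparable step in hand, the step from compound 2 to compound 3 is expected to stay within the usual scatter, in no preferred direction: a 1.2-fold lower number from compound 2 to compound 3 (0.07 log units; within the scatter). Compound 3 is therefore estimated at 22000 nM, with a range from 7000 nM to 50000 nM, and a fair chance that this assay again returns only a limit.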

Compound 3, half-maximal inhibitory concentration: > 50000 nM
Compound 3: only a limit was reported; the forecaster's own chance of this, stated with the estimate: 30%; middle value at least 2.2-fold (0.35 log units) from the limit.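

Within the data shown here, the first measured step at this place, on the nitrogen on an aromatic ring, comes from 3,4-dimethoxyphenyl in place of 3-bromophenyl in this assay: an at least 1.9-fold higher number from compound 2 to compound 3 (0.29 log units; that floor lies within the scatter). The result for compound 3 is a limit, so this step has a floor but no known size, and that floor does not separate the change from the scatter. Compound 2 remains the only compound with a number, and the readout now offers little room to compare changes at this place: the limit of > 50000 nM in this assay, at which 2 of the 3 values shown sit.

Going by these compounds, it remains open whether the bromine itself matters, which a plain phenyl or a 3-chlorophenyl on the same nitrogen would test. On these data alone, it is also open whether a carboxylic acid or an amine on that ring would give a number lower than that of compound 2.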